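A few compounds are considered here, and "the series" means these few. Any claim that something is new, unique, unknown or untested is made for them only; others in the source may bear on it.

Working notes on the amide series around the shared core of compound 1 `O=C(N[C@@H]1CCNC1)c1cc(-c2ccc(NS(=O)(=O)c3cccc(Cl)c3Cl)cc2)nc2[nH]ncc12`.

In an assay for inhibition of serine/threonine-protein kinase Sgk1 (Homo sapiens), with stated times of 30 min and 60 min, in the presence of a further agent that is not named here (on this read-out higher numbers stand for weaker inhibition and lower numbers for stronger inhibition), compound 1 gives < 1 nM, which is a limit of the assay rather than a number (the limit of < 1 nM in this assay, at which 1 of the 3 values shown sits). Compound 2 `NC(=O)c1cc(-c2ccc(NS(=O)(=O)c3cccc(Cl)c3Cl)cc2)nc2[nH]ncc12` carries hydrogen on the amide-type nitrogen; in this assay compound 2 gives 236 nM. The step of an at least 230-fold higher number from compound 1 to compound 2 (2.37 log units; beyond the scatter). Compound 3 `CCNC(=O)c1cc(-c2ccc(NS(=O)(=O)c3cccc(Cl)c3Cl)cc2)nc2[nH]ncc12` carries ethyl on the same nitrogen. In this assay compound 3 gives < 1920 nM, which is again a limit and not a number (the limit of < 1920 nM in this assay, at which 1 of the 3 values shown sits). Where compound 3 stands among the three is therefore open: the step that the two limits leave unreadable from compound 1 to compound 3, and the step that the limit leaves unreadable from compound 2 to compound 3.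

Compound 4 `NCCNC(=O)c1cc(-c2ccc(NS(=O)(=O)c3cccc(Cl)c3Cl)cc2)nc2[nH]ncc12` differs from compound 3 by amino in place of hydrogen on a saturated chain carbon, two bonds along the chain from an amide-type nitrogen. Of the measured steps, the only one with readable size is the move from compound 1 to compound 2, where removal of the ring bearing an amino function cost a great deal; compound 4 restores an amino function on the chain, though without the ring. A fall in this assay is expected from compound 3 to compound 4, of size a step that the limit leaves unreadable from compound 3 to compound 4, with the two limits leaving the start point loose. For compound 4 in this assay a value of about 8 nM is estimated, expected to fall between 1 nM and 60 nM.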

Compound 4, half-maximal inhibitory concentration: < 1 nM
Compound 4: no number, only a limit (the forecaster's own chance of this, stated with the estimate: 25%); middle value at least 8.0-fold (0.90 log units) from the limit.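

In this assay the open-chain 2-aminoethyl group on the amide-type nitrogen gives a large step, an at least 230-fold lower number from compound 2 to compound 4 (2.37 log units; beyond the scatter), so the ring of compound 1 is not required for a change of this size at this position. Compound 4 gives < 1 nM, which is a limit of the assay and the same limit as for compound 1: the limit of < 1 nM in this assay, at which 2 of the 4 values shown sit. The link between an amino function on this substituent and a value at that limit rests on compound 1 and compound 4 set against compound 2, while compound 3, with ethyl, can neither support nor go against it.

The steps from compound 3 to compound 4 and from compound 1 to compound 4 cannot be read, so neither the share of the amino group alone nor any order between the ring and the chain can be stated. Also open, on these data alone, is whether 3-aminopropyl as a longer chain, a dimethylamino group at the chain end, or a hydroxyl or carboxylic acid in place of the amino group would stay at this limit.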